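Halogen Swap at the Cytotoxicity Limit

The source may report more compounds than this note shows. Statements on the series, on what has been measured and on what is new or still open speak of the compounds shown alone.

Two compounds of one series share a core and differ only in which halogen sits on each of two aromatic rings. Compound 1 `CO[C@@H]1[C@H](N(C)c2ncc(-c3c[nH]c4ccc(Br)cc34)s2)C[C@H]2O[C@]1(C)n1c3ccccc3c3c4c(c5c6cc(Cl)ccc6n2c5c31)C(=O)NC4` was tested in an ADME assay on PBMC cells (Homo sapiens) for cytotoxicity, read by CellTiter-Glo, with a stated time of 72 h; a lower number here means a stronger inhibitor, a higher number a weaker inhibitor. In this assay compound 1 gives > 10000 nM, which is a limit of the assay and not a measured number. Compound 2 `CO[C@@H]1[C@H](N(C)c2ncc(-c3c[nH]c4ccc(Cl)cc34)s2)C[C@H]2O[C@]1(C)n1c3ccccc3c3c4c(c5c6cc(Br)ccc6n2c5c31)C(=O)NC4` carries the two halogens the other way round. In this assay compound 2 gives > 10000 nM, again a limit rather than a number. Compound 2 therefore stands at the limit of > 10000 nM in this assay, at which 2 of the 2 values shown sit. Compound 3 `CO[C@@H]1[C@H](N(C)c2ncc(-c3c[nH]c4ccc(Br)cc34)s2)C[C@H]2O[C@]1(C)n1c3ccccc3c3c4c(c5c6cc(Br)ccc6n2c5c31)C(=O)NC4` differs from compound 2 by bromo in place of chloro on an aromatic carbon. Among the measured compounds shown here, no step between measured compounds exists to calibrate this change, and both values shown are limits. No step beyond the usual scatter is expected in this assay. The estimated step is a step that the limit leaves unreadable from compound 2 to compound 3. Compound 3 is estimated at 15000 nM, within 7000 nM to 40000 nM, and is expected most likely to be reported only as a limit.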

Compound 3, half-maximal inhibitory concentration: > 10000 nM
Compound 3: a limit, no number; the forecaster's own chance of this, stated with the estimate: 85%; the middle value lies beyond the limit too.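

In this assay compound 3 gives > 10000 nM, a limit of the assay and not a number. Among the compounds shown here, no step from compound 1 or compound 2 to compound 3 can be read: the limit of > 10000 nM in this assay, at which 3 of the 3 values shown sit. The compounds shown leave open whether bromo in place of chloro changes the half-maximal inhibitory concentration at all.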